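The compounds below may be only part of what the source reports. "The series", "measured", "known", "first", "only" and "open" are said of these compounds alone.

Compound 1 `ClCc1ccc(Cn2cnc3c(Cl)ncnc32)cc1` and compound 2 `Nc1nc(Cl)c2ncn(Cc3ccc(CCl)cc3)c2n1` share one core and differ only at a single position. In a functional assay on BT-549 cells (Homo sapiens) for cytotoxicity, read by sulforhodamine B assay, with a stated time of 48 h (on this read-out lower numbers stand for stronger inhibition of growth and higher numbers for weaker inhibition of growth), compound 1 gives 21400 nM, and compound 2 gives 24600 nM. The change between them, (amino in place of hydrogen on an aromatic carbon), produced a step of a 1.1-fold higher number from compound 1 to compound 2 (0.06 log units; within the scatter), so the two values are not distinguished by this measurement.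

Compound 3 `ClCc1ccccc1Cn1cnc2c(Cl)ncnc21` carries the same atoms as compound 1 joined differently; the difference between the two cores is not broken down here. In this assay compound 3 gives 5490 nM, which is the lowest of the three numbers measured, standing beyond the scatter from both compound 1 and compound 2.

Compound 4 `Nc1nc(Cl)c2ncn(Cc3ccccc3CCl)c2n1` has not yet been measured. It differs from compound 3 by amino in place of hydrogen on an aromatic carbon, and the place of the change is described in exactly the same words as for the change from compound 1 to compound 2, so it is the same change made on a different core. Because the earlier instance gave a 1.1-fold higher number from compound 1 to compound 2 (0.06 log units; within the scatter), the step from compound 3 to compound 4 is expected to be small as well, estimated at a 1.1-fold higher number from compound 3 to compound 4 (0.06 log units; within the scatter). Taking compound 3 at 5490 nM as the starting point, compound 4 is expected to give about 6300 nM in this assay, with a likely range from 3000 nM to 13000 nM.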

Compound 4, concentration for total growth inhibition: 22900 nM
For compound 4 the middle estimate is 3.6-fold (0.56 log units) below the measured one, outside the stated range (above it).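

In this assay, amino in place of hydrogen on an aromatic carbon gave a 4.2-fold higher number from compound 3 to compound 4 (0.62 log units; beyond the scatter), whereas the same change gave a 1.1-fold higher number from compound 1 to compound 2 (0.06 log units; within the scatter), a step that this measurement does not separate from no change at all. The size of this step therefore does not carry over unchanged from one core to the other in this series: the same change on two cores in this assay, a 1.1-fold higher number (0.06 log units; within the scatter) from compound 1 to compound 2 and a 4.2-fold higher number (0.62 log units; beyond the scatter) from compound 3 to compound 4, 3.6-fold (0.56 log units) apart, beyond the scatter of two such steps This shows that a step read on one of these cores is not a safe guide to the other, but it rests on just two pairs of compounds and does not show why the cores differ, nor how the change would behave on any further core.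

The compounds shown leave open whether another group on the same aromatic carbon between two ring nitrogen atoms, such as a methylamino group or a hydroxyl group, would also give steps that differ between the two cores. They also leave open whether the difference between the steps would persist if the chloro group were replaced by a morpholine or a methoxy group, or how the change would read on cell lines other than the one tested here.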